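The source may report more compounds than this note shows. Statements on the series, on what has been measured and on what is new or still open speak of the compounds shown alone.

Of the compounds shown here, two sharing one core have so far been tested in a functional assay on HL-60 cells (Homo sapiens) for inhibition, read by resazurin assay, with a stated time of 72 h; a lower number here means a stronger inhibitor, a higher number a weaker inhibitor. Compound 1, `C=CC1C(=O)N(c2cc(OC)c(OC)c(OC)c2)C1c1ccc(OC)cc1`, gives 33 nM. Compound 2, `COc1cc(N2C(=O)C(O)C2c2ccc(SC)cc2)cc(OC)c1OC`, gives 15 nM, the lower of the two numbers; compound 1 is its nearest neighbour, and the gap between them lies beyond the usual scatter. These two structures differ in more than one place, so no single step can be read between them. Compound 3, `C=CC1C(=O)N(c2cc(OC)c(OC)c(OC)c2)C1c1ccc(SC)cc1`, is not yet measured. It differs from compound 2 in one place: vinyl in place of hydroxy on a saturated ring carbon. Going by the values given here, no measured pair shows this exchange on its own, so its effect cannot be taken from the data, and a step of modest size, in either direction or none beyond the scatter, is what one would expect. The step of a 1.3-fold higher number from compound 2 to compound 3 (0.12 log units; within the scatter) is expected to be small. For compound 3 the estimate is 20 nM, within a range from 7 nM to 60 nM.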

Compound 3, half-maximal inhibitory concentration: 61 nM
The estimate for compound 3 lay 3.1-fold (0.48 log units) below the measured number; the measured number lies above the stated range.
By their numbers in this assay, from the lowest: compound 2; then compounds 1 and 3 (each within the scatter of the next).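

In this assay, placing vinyl instead of hydroxy on this saturated ring carbon gives a 4.1-fold higher number from compound 2 to compound 3 (0.61 log units; beyond the scatter), so with the 4-(methylsulfanyl)phenyl group in place, the group at this position clearly changes the number, and hydroxy gives the stronger inhibitor. By contrast, methylsulfanyl in place of methoxy on an aromatic carbon, with vinyl on the ring carbon, gives a 1.8-fold higher number from compound 1 to compound 3 (0.27 log units; within the scatter), so this exchange shows no clear effect on its own. No measurement shown here explains why the two groups on the ring carbon differ.

As far as these compounds go, only hydroxy and vinyl appear at this ring carbon, so how an amine, a methyl group or a longer chain would read there remains open. Also open, from the compounds shown here alone, is whether methoxy and methylsulfanyl would read alike with hydroxy on that carbon.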